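A few compounds are considered here, and "the series" means these few. Any claim that something is new, unique, unknown or untested is made for them only; others in the source may bear on it.

Of the compounds shown here, two of a shared core have been measured in a functional assay on MCF7 cells (Homo sapiens) for antiproliferative activity, read by sulforhodamine B assay, with a stated time of 72 h; a lower number here means a stronger inhibitor, a higher number a weaker inhibitor. Compound 1 `FC(F)(F)c1ccc(CN2CCN(Cc3cc(-c4ccc(OCc5ccccc5)cc4)on3)CC2)cc1` gives 2900 nM in this assay. Compound 2 `N#Cc1cccc(COc2ccc(-c3cc(CN4CCN(c5ccc(C(F)(F)F)cc5)CC4)no3)cc2)c1` gives 2000 nM in this assay. Compound 2 thus shows the lower of the two numbers, but its gap to compound 1 lies within the scatter of repeated measurements, so the two cannot be ranked against each other on this evidence.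

Compound 3 `N#Cc1cccc(COc2ccc(-c3cc(CN4CCN(C(=O)C5CCCO5)CC4)no3)cc2)c1` has not yet been measured in this assay. It differs from compound 2 in one place: (oxolan-2-yl)carbonyl in place of 4-(trifluoromethyl)phenyl on an amine nitrogen in a ring. For the measured compounds named here, no pair of measured compounds shows a change of this kind, so no measured step can be borrowed for it. Both measured compounds carry a 4-(trifluoromethyl)phenyl group, and compound 3 would be the first without one, which leaves the direction of the step open to guesswork. In this assay the expected step is a 2.5-fold higher number from compound 2 to compound 3 (0.40 log units; beyond the scatter), a modest weakening that may still fall within the scatter. Compound 3 is therefore estimated at 5000 nM in this assay, with a range from 1500 nM to 15000 nM.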

Compound 3, half-maximal inhibitory concentration: 3800 nM
Beside the measured number, compound 3's estimate is 1.3-fold (0.12 log units) above it; measured number inside the range.
By their numbers in this assay, from the lowest: compounds 2, 1 and 3 (each within the scatter of the next).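

Compounds 1 and 2 both carry a 4-(trifluoromethyl)phenyl group, so they could not show how this assay responds when that group is absent from the shared core. Compound 3 supplies that test: placing (oxolan-2-yl)carbonyl on the amine nitrogen in the ring gives a 1.9-fold higher number from compound 2 to compound 3 (0.28 log units; within the scatter), so this exchange cannot be told apart from no change on this evidence, even though the entering group has no aromatic ring, has fewer heavy atoms and adds two oxygens with 2 hydrogen-bond acceptors. For the compounds shown here, the single step therefore shows that, at this position, a 4-(trifluoromethyl)phenyl group is not required for a reading within the scatter of compound 2, while no measurement offered here explains that outcome.

The compounds shown leave open whether this result depends on the carbonyl or on the oxolane ring, which an acetyl group or a plain oxolan-2-ylmethyl group on the same nitrogen could separate. They also leave open whether a carboxylic acid or a primary amine carried on that ring would give a step beyond the scatter.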